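The compounds below may be only part of what the source reports. "The series", "measured", "known", "first", "only" and "open" are said of these compounds alone.

The measured compounds in an in vitro functional assay on RBL cells for antagonist activity at C-C chemokine receptor type 8 (Homo sapiens), read by FLIPR and calcium flux (a lower number here means a stronger inhibitor, a higher number a weaker inhibitor), are three. Compound 1, `O=C1OC(c2ccnc3ccccc23)CN1C1CCN(Cc2cc3ccccc3[nH]2)CC1`, gives 1000 nM. Compound 2, `O=C1OC(c2ccncc2)CN1C1CCN(Cc2cc3ccccc3[nH]2)CC1`, gives < 50200 nM, which is a limit of the assay and not a number. Compound 3, `COc1ccc2nccc(C3CN(C4CCN(Cc5cc6ccccc6s5)CC4)C(=O)O3)c2c1`, gives 794 nM.

Compound 3 holds the lowest of the two numbers, with compound 1 nearest; the gap between the two lies within the scatter, so no order between them can be read. Among the compounds with values here, the only step between measured compounds that differ in one place is a step that the limit leaves unreadable from compound 1 to compound 2; the limit of < 50200 nM in this assay, at which 1 of the 3 values shown sits, leaves its size unreadable, and it concerns a different part of the molecule. Compound 4, `COc1ccc2nccc(C3CN(C4CCN(CCCc5ccccc5)CC4)C(=O)O3)c2c1`, differs from compound 3 by phenethyl in place of 1-benzothiophen-2-yl on a saturated chain carbon bound to an amine nitrogen in a ring. Within the data shown here, no measured step bears on this change, so the expectation rests only on where compound 3 stands. Compound 4 is expected to sit near compound 3 or somewhat weaker, a step of a 2.5-fold higher number from compound 3 to compound 4 (0.40 log units; beyond the scatter). The estimate for compound 4 is 2000 nM, with a range from 500 nM to 8000 nM.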

Compound 4, half-maximal inhibitory concentration: 251 nM
The estimate for compound 4 lay 8.0-fold (0.90 log units) above the measured number, and the stated range ends above it.
By their numbers in this assay, from the lowest: compound 4; then compounds 3 and 1 (each within the scatter of the next).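

In this assay, the place on a saturated chain carbon bound to an amine nitrogen in a ring tolerates a clear change of group: phenethyl in place of 1-benzothiophen-2-yl gives a 3.2-fold lower number from compound 3 to compound 4 (0.50 log units; beyond the scatter) and leaves the shared core untouched. The five-membered aromatic ring with its sulfur is therefore not needed for compound 4 to hold a number of this size, and a six-membered aromatic ring of carbon only suffices in this one pair. Nothing measured here accounts for the size of this step.

The same difference also reads as (1-benzothiophen-2-yl)methyl to 3-phenylpropyl, so the ring and the chain change together and their shares cannot be separated. Going by these compounds, how a benzyl group, a longer chain or a pyridine ring at the chain end would read at this place remains open.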